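The source may report more compounds than this note shows. Statements on the series, on what has been measured and on what is new or still open speak of the compounds shown alone.

Measured compounds:
compound 1, `Cc1cccc(N2CCN(C(=O)CN3C(=O)CC(C)(c4ccccc4)C3=O)CC2)c1`, "not active" (no number reported)
compound 2, `COc1cccc(N2CCN(C(=O)CN3C(=O)CC(C)(c4ccccc4)C3=O)CC2)c1`, 100 mg/kg
compound 3, `CC1(c2ccccc2)CC(=O)N(CC(=O)N2CCN(c3ccccc3)CC2)C1=O`, 100 mg/kg

In a functional assay on the whole organism (strain CD-1) with Mus musculus as the target, with a stated time of 0.5 h (on this read-out lower numbers stand for an effect already at smaller amounts and higher numbers for an effect only at larger amounts of compound), compound 3 stands level with compound 2 at the digits reported, and the step of no change at the digits printed from compound 2 to compound 3 (within the scatter) lies within the scatter. Going by the values given here, compound 1 is the one further entry, and for it only "not active" was reported, without a number, so no step to it can be sized.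

Compound 4, `COc1ccccc1N1CCN(C(=O)CN2C(=O)CC(C)(c3ccccc3)C2=O)CC1`, differs from compound 3 by methoxy in place of hydrogen on an aromatic carbon. Among the compounds with values here, the only measured step that bears on this change is the one from compound 2 to compound 3, the same kind of group leaving an aromatic carbon, and that step, no change at the digits printed from compound 2 to compound 3 (within the scatter), was flat. Nothing measured here speaks for a methoxy at this particular aromatic carbon, and compound 1 warns that a small group on the same ring can leave a compound with no reported number at all.

The expectation is therefore a step of no change at the digits printed from compound 3 to compound 4 (within the scatter) of no size beyond the scatter. For compound 4 the estimate in this assay is 100 mg/kg, with a range from 50 mg/kg to 200 mg/kg, allowing for the possibility that, like compound 1, only "not active" is reported.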

Compound 4, minimum effective dose: "not active" (no number reported)
For compound 4 the study gives words and no number; the estimate stays without a comparison.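

In this assay, going by these compounds alone, compound 4 is reported as "not active" (no number reported), so no step from compound 3 to compound 4 can be read. The compounds shown leave open how the 2-methoxyphenyl of compound 4 compares in size of effect with the phenyl of compound 3. Nothing given here accounts for this result.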